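This account rests on a few compounds, and the source may have more. Where it says the series, first, only, none or still open, it means among the compounds named here.

Measured so far:
compound 1, `CNC(=O)CCc1ccncc1-c1ccc2ccccc2c1`: 21.1 nM
compound 2, `CNC(=O)/C=C/c1ccncc1-c1ccc2c(ccn2C)c1`: 77.6 nM
compound 3, `O=C(O)/C=C/c1ccncc1-c1ccc2[nH]ccc2c1`: 17 nM

In an assay on a protein complex for inhibition of CDK8/Cyclin C (Homo sapiens), with a stated time of 1 h (on this read-out higher numbers stand for weaker inhibition and lower numbers for stronger inhibition), compound 1 gives 21.1 nM, the second highest of the three numbers. Compound 3 sits within the scatter of it, while compound 2 lies well beyond, at a higher number. Compound 4, `CN(C)C(=O)/C=C/c1ccncc1-c1ccc2ccccc2c1`, has not yet been measured. It differs from compound 1 in one place: 2-(dimethylcarbamoyl)ethenyl in place of 2-(methylcarbamoyl)ethyl on an aromatic carbon. Compounds 2 and 3 both carry the unsaturated linker and still bind, so the new linker need not cost much; the loss of the amide hydrogen is the open question. For compound 4 a small step toward a higher number, not clearly beyond the scatter, is expected, a 1.9-fold higher number from compound 1 to compound 4 (0.28 log units; within the scatter). The estimated value of compound 4 is 40 nM, within 12 nM to 130 nM.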

Compound 4, half-maximal inhibitory concentration: 30.1 nM
Compound 4: the middle estimate sits 1.3-fold (0.12 log units) above what was measured; low and high end bracket the measured number.
By their numbers in this assay, from the lowest: compounds 3, 1 and 4 (each within the scatter of the next); then compound 2.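

In this assay the change at this position gives a 1.4-fold higher number from compound 1 to compound 4 (0.15 log units; within the scatter) and so leaves the number within the usual scatter. The position therefore tolerates losing the hydrogen-bond donor and gaining a double bond in the same step, and the amide hydrogen of compound 1 is not needed to keep a similar number. No measurement shown here explains this result. Still open, from the compounds shown here alone, is how each of the two changes would read alone, and how an amine or a longer chain would fare at this position.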